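Methyl in Place of tert-Butyl: Effect on Cytotoxicity

A few compounds are considered here, and "the series" means these few. Any claim that something is new, unique, unknown or untested is made for them only; others in the source may bear on it.

Compound 1, `Fc1ccc(-c2nnc3nnc(N4CCCC4)n3n2)cc1`, gives > 100000 nM.
Compound 2, `O=[N+]([O-])c1ccc(-c2nnc3nnc(N4CCCCC4)n3n2)cc1`, gives > 100000 nM.
Compound 3, `CC(C)(C)c1nnc2nnc(N3CCCC3)nn12`, gives 12500 nM.

The reading of compound 1 is a limit of the assay, not a number. The same holds for compound 2. Two of the three readings sit at the limit of > 100000 nM in this assay, at which 2 of the 3 values shown sit. Among the compounds with values here, in a functional assay on BeWo cells (Homo sapiens) for cytotoxicity, read by MTT assay, with a stated time of 72 h (a lower number here means a stronger inhibitor, a higher number a weaker inhibitor), compound 3 therefore stands as the only compound with a number, and nothing measured tells how far its value can be trusted as a guide. Compound 4, `Cc1nnc2nnc(N3CCCC3)nn12`, differs from compound 3 only by methyl in place of tert-butyl on an aromatic carbon. Within the data shown here, no measured step of this kind exists here, so the expectation rests on the single number for compound 3. The step of a 2.4-fold higher number from compound 3 to compound 4 (0.38 log units; beyond the scatter) is expected to be modest, toward weaker, and compound 4 is estimated at 30000 nM, within 8000 nM to 110000 nM.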

Compound 4, half-maximal inhibitory concentration: 5360 nM
For compound 4 the middle estimate is 5.6-fold (0.75 log units) above the measured one, outside the stated range (below it).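

In this assay, putting methyl in place of tert-butyl on this aromatic carbon gives a 2.3-fold lower number from compound 3 to compound 4 (0.37 log units; beyond the scatter), so here the smaller group gives the stronger inhibitor. Within the data shown here, the first measured step at this position thus shows that the extra carbons of tert-butyl are not needed to keep the cytotoxic effect. No measurement shown accounts for the direction of this step.

Two points are left open: whether the change continues in the same direction with a hydrogen atom on this carbon, and how an ethyl chain, an amine or a carboxylic acid would compare there.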